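This account rests on a few compounds, and the source may have more. Where it says the series, first, only, none or still open, it means among the compounds named here.

Among the measured compounds shown here, in a functional assay on HeLa cells (Homo sapiens) for inhibition, read by MTT assay, with a stated time of 72 h (a higher number here means a weaker inhibitor, a lower number a stronger inhibitor), compound 1 `Fc1ccc(-c2nnc(SCCCN3CCN(c4nc5ccccc5s4)CC3)o2)cc1` gives 134000 nM and compound 2 `Brc1ccc(-c2nnc(SCCCN3CCN(c4nc5ccccc5s4)CC3)o2)cc1` gives 243000 nM, so these two cannot be told apart: the only measured step, a 1.8-fold higher number from compound 1 to compound 2 (0.26 log units; within the scatter), lies within the scatter. Compound 3 `CC(C)(C)Oc1ccc(-c2nnc(SCCCN3CCN(c4nc5ccccc5s4)CC3)o2)cc1` differs from compound 2 at the same aromatic carbon, with tert-butoxy in place of bromo on an aromatic carbon. That single step, one halogen swapped for another, offers only a weak guide to this change, so no shift beyond the scatter is expected. The expected step is a 1.4-fold lower number from compound 2 to compound 3 (0.16 log units; within the scatter). For compound 3 the estimated value is 170000 nM, with an expected range of 60000 nM to 400000 nM.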

Compound 3, half-maximal inhibitory concentration: 217000 nM
Compound 3: the middle estimate sits 1.3-fold (0.11 log units) below what was measured; the measured number falls inside the stated range.
By their numbers in this assay, from the lowest: compounds 1, 3 and 2 (each within the scatter of the next).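

In this assay, putting tert-butoxy, with its five heavy atoms and one hydrogen-bond acceptor, in place of a single bromine on this aromatic carbon leaves the number where it was (a 1.1-fold lower number from compound 2 to compound 3 (0.05 log units; within the scatter)). The comparison with fluoro reads the same (a 1.6-fold higher number from compound 1 to compound 3 (0.21 log units; within the scatter)), so even this much larger group brings no readable change, and all three compounds lie within the scatter of each other. Nothing measured here bears on why this position responds so little. The compounds shown leave open whether an amine or a carboxylic acid on this carbon would move the number beyond the scatter.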